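A Fluoro-to-Hydrogen Swap on the Cyanophenyl Ring

The source may hold more compounds than are shown below. What is called first, only, known or untested is meant among the compounds shown, and "the series" means these compounds.

Of the compounds shown here, three have been measured in an in vitro functional assay on HEK293-A cells for agonist activity at metabotropic glutamate receptor 5 (Rattus norvegicus), read by ELISA; on this read-out lower numbers stand for stronger inhibition and higher numbers for weaker inhibition. Compound 1 `CCc1cccc(C#Cc2cccc(C#N)c2)n1` gives 80 nM. Compound 2 `N#Cc1cc(F)cc(C#Cc2cccc(F)n2)c1` gives 80 nM, level with compound 1 at the digits shown, and the two together stand at the highest numbers of the three. Among the measured compounds shown here, compound 3 `Cc1cccc(C#Cc2cc(F)cc(C#N)c2)n1` gives 2.4 nM; the one measured single-place step, a 33-fold lower number from compound 2 to compound 3 (1.52 log units; beyond the scatter), is a methyl in place of fluoro on an aromatic carbon of the core.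

Compound 4 `N#Cc1cccc(C#Cc2cccc(F)n2)c1` has not yet been measured. Its difference from compound 2 is hydrogen in place of fluoro on an aromatic carbon, a hydrogen in place of fluoro on an aromatic carbon of the six-membered aromatic ring of carbon only, meta to the cyano group and meta to the group of 9 heavy atoms. For the measured compounds named here, no measured step in this set changes that same position; the large step from compound 2 to compound 3 sits elsewhere in the molecule, so it offers no direct guide here. Going by the values given here, with no step bearing on the removed fluoro, the expected change in this assay is none beyond the scatter. Compound 4 is therefore estimated at 90 nM, within 30 nM to 270 nM, an expected step of a 1.1-fold higher number from compound 2 to compound 4 (0.05 log units; within the scatter).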

Compound 4, half-maximal inhibitory concentration: 210 nM
Compound 4: middle estimate off by 2.3-fold (0.37 log units), on the low side, within the range that was stated.
By their numbers in this assay, from the lowest: compound 3; then compounds 1 and 2 (each within the scatter of the next); then compound 4.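

In this assay, taking the fluoro off the six-membered aromatic ring of carbon only gives a 2.6-fold higher number from compound 2 to compound 4 (0.42 log units; beyond the scatter), so this position does respond to the change, modestly but beyond the scatter, and in this pair the fluoro goes with the lower number. Compound 4 also opens a second comparison, at the other substituted aromatic carbon, where both partners carry hydrogen on the cyano-bearing ring: fluoro in place of ethyl gives a 2.6-fold higher number from compound 1 to compound 4 (0.42 log units; beyond the scatter), which points the same way as the methyl-for-fluoro change in a 33-fold lower number from compound 2 to compound 3 (1.52 log units; beyond the scatter), although that larger step was measured with the ring fluoro present. No measurement at hand explains why either change moves the number.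

Going by these compounds, the effect of the ring fluoro rests on this single pair, so it remains open whether hydrogen in its place would raise the number by a similar amount when methyl or ethyl sits at the other carbon. Also open, on these data alone, is how chloro, methoxy or an amine would read at the same ring position, and so whether fluoro is a special case or one of many groups that would serve there.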